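This account rests on a few compounds, and the source may have more. Where it says the series, first, only, none or still open, it means among the compounds named here.

Two close relatives of a shared core have been tested in a functional assay on NCI-H460 cells (Homo sapiens) for inhibition, read by sulforhodamine B assay, with a stated time of 48 h; a higher number here means a weaker inhibitor of growth, a lower number a stronger inhibitor of growth. Among the compounds with values here, compound 1 `COC(=O)c1sc2cc(-c3cnn(C)c3)cnc2c1N` is the first. In this assay compound 1 gives only a limit, > 150000 nM, not a measured number. Compound 2 `COC(=O)c1sc2cc(-c3ccc(C(C)=O)cc3)cnc2c1N` is the second, with an acetyl on a six-membered aromatic ring of carbon only. In this assay compound 2 likewise reaches only a limit, > 150000 nM. Within the data shown here, compound 2 therefore stands where every value so far stands: at the limit, with no number that would set it apart from compound 1, as the limit of > 150000 nM in this assay, at which 2 of the 2 values shown sit, sums up. Compound 3 `COC(=O)c1sc2cc(-c3ccc(OC)cc3)cnc2c1N` has not yet been measured. It differs from compound 2 in one place: methoxy in place of acetyl on an aromatic carbon. Among the measured compounds shown here, no step between two measured compounds exists to show how large a change of this kind has been; the only guide is that both measured compounds sit at the limit. From that, the expected step is a step that the limit leaves unreadable from compound 2 to compound 3, small or none beyond the scatter, and the assay will most likely again report only a limit. Compound 3 is thus estimated at 200000 nM, within a range from 60000 nM to 600000 nM.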

Compound 3, concentration for 50% growth inhibition: > 150000 nM
Compound 3 ended at the assay's limit; the forecaster's own chance of this, stated with the estimate: 80%; the middle value is on the limit's open side.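

No step can be read between compound 2 and compound 3, because in this assay each gives only a limit and not a number: the limit of > 150000 nM in this assay, at which 3 of the 3 values shown sit. The compounds shown leave open how strongly, if at all, any of them inhibits growth, and which change to the shared core would yield a measurable value.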